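Trifluoromethyl for Methyl on a Chloro-Substituted Amide Core

The source may report more compounds than this note shows. Statements on the series, on what has been measured and on what is new or still open speak of the compounds shown alone.

Measured compounds:
compound 1, `Cc1ccc(C(=O)Nc2nc(Cl)c3cn(C)nc3n2)cc1`: > 20000 nM
compound 2, `Cn1cc2c(Cl)nc(N)nc2n1`: > 20000 nM

Of the compounds shown here, two have been measured in a functional assay on CHO cells for antagonist activity at adenosine receptor A2b (Homo sapiens), read by 33P incorporation, with a stated time of 20 min, in the presence of a further agent that is not named here; a higher number here means a weaker inhibitor, a lower number a stronger inhibitor. For compound 1 the assay gives only a limit, > 20000 nM. For compound 2 the assay likewise gives only a limit, > 20000 nM. Within the data shown here, both values thus sit at the limit of > 20000 nM in this assay, at which 2 of the 2 values shown sit, so compound 1 cannot be placed above or below compound 2, and no measured step between two compounds with definite numbers exists in this set.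

The next compound, compound 3 `Cn1cc2c(Cl)nc(NC(=O)c3ccc(C(F)(F)F)cc3)nc2n1`, keeps the core of compound 1 and changes one group: trifluoromethyl in place of methyl on an aromatic carbon. Among the measured compounds shown here, since no measured step is available, the size of the change from compound 1 to compound 3 in this assay is unknown in advance, and compound 1 itself offers only a limit to start from.

The estimate for compound 3 is therefore an expected value of 20000 nM, with a range from 5000 nM to 60000 nM. This corresponds to an expected step of a number no higher from compound 1 to compound 3 (the limit leaves the size open) that does not go beyond the scatter, with a substantial chance that the assay again reports only a limit for compound 3.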

Compound 3, inhibition constant: > 20000 nM
Compound 3: a limit, no number (the forecaster's own chance of this, stated with the estimate: 70%); the middle value sits exactly at the limit.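

In this assay compound 3 gives > 20000 nM as a limit and not a number. Among these compounds, compound 1 also carries only a limit, so no step between compound 1 and compound 3 can be read: the limit of > 20000 nM in this assay, at which 3 of the 3 values shown sit. The compounds shown leave open whether trifluoromethyl and methyl differ at all here, and what definite value any of these compounds would have.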